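A few compounds are considered here, and "the series" means these few. Any claim that something is new, unique, unknown or untested is made for them only; others in the source may bear on it.

Working notes on the chloroacetamide series in a functional assay on NCI-H460 cells (Homo sapiens) for antiproliferative activity, read by MTT assay, with a stated time of 48 h; on this read-out higher numbers stand for weaker inhibition and lower numbers for stronger inhibition.

Compound 1 `O=C(CSc1nnc(NC(=O)CCl)s1)Nc1ccc(Br)cn1` gives 7500 nM. Among the measured compounds shown here, compound 2 `O=C(CSc1nnc(NC(=O)CCCl)s1)Nc1ccc(Br)cn1`, which carries chloromethyl in place of chloro on a saturated chain carbon bound to a carbonyl carbon, gives 560 nM; the step of a 13-fold lower number from compound 1 to compound 2 (1.13 log units; beyond the scatter) is the only measured instance of this change so far.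

Compound 3 `O=C(CCl)Nc1ccc(SCC(=O)Nc2cc(Cl)ccn2)cc1` sits on a different core; the difference between the core of compound 3 and the core of compound 1 is not broken down here. Compound 3 gives 5600 nM, a value within the scatter of compound 1, so the two are treated as equivalent.

Compound 4 `O=C(CCCl)Nc1ccc(SCC(=O)Nc2cc(Cl)ccn2)cc1` is the analogue of compound 3 that carries chloromethyl in place of chloro on a saturated chain carbon bound to a carbonyl carbon, the same change as in compound 2, at the same kind of position. For the measured compounds named here, on the core of compound 1 the change produced a 13-fold lower number from compound 1 to compound 2 (1.13 log units; beyond the scatter); with only that single precedent, and on a core that is not the same, the step from compound 3 to compound 4 is expected to be of similar direction but somewhat uncertain in size, estimated at an 8.0-fold lower number from compound 3 to compound 4 (0.90 log units; beyond the scatter). On that basis compound 4 is expected to give about 700 nM, estimated to lie between 250 nM and 2500 nM.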

Compound 4, half-maximal inhibitory concentration: 10900 nM
The estimate for compound 4 lay 16-fold (1.19 log units) below the measured number; measured number outside the range, above it.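

The gain seen on the core of compound 1 does not carry over to the core of compound 3 in this assay: the same change on two cores in this assay, a 13-fold lower number (1.13 log units; beyond the scatter) from compound 1 to compound 2 and a 1.9-fold higher number (0.29 log units; within the scatter) from compound 3 to compound 4, 26-fold (1.42 log units) apart, beyond the scatter of two such steps

On the second core the change gives a 1.9-fold higher number from compound 3 to compound 4 (0.29 log units; within the scatter), so compound 3 and compound 4 count as equivalent and no reversal of direction is claimed. With a single pair on each core, this shows that the effect of chloromethyl in place of chloro depends on the core in these compounds, but it does not show which structural difference between the cores is responsible, or whether either step would hold for other members on the same core.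

Open, as far as these compounds go, is how a longer chain, such as 3-chloropropyl, would read on each of the two cores. Also open, from the compounds shown here alone, is whether the chlorine matters to either step, which a plain ethyl group in place of 2-chloroethyl would test.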